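Linker swap on the shared core of compound 1

This account rests on a few compounds, and the source may have more. Where it says the series, first, only, none or still open, it means among the compounds named here.

Working notes on the shared core of compound 1 `Nc1cc(N)c2nc(-c3ccccc3)c(Sc3ccc(F)cc3)nc2c1`. Among the measured compounds shown here, in a functional assay on SNB-19 cells (Homo sapiens) for inhibition, read by sulforhodamine B assay, with a stated time of 48 h (on this read-out higher numbers stand for weaker inhibition of growth and lower numbers for stronger inhibition of growth), compound 1 gives 41700 nM, the only numerical value in this set. Compound 2 `CCOC(=O)[C@H](CCC(=O)O)NC(=O)c1ccc(Oc2nc3cc(N)cc(N)c3nc2-c2ccccc2)cc1` returns only a limit in this assay, < 100000 nM. Compound 3 `CCOC(=O)[C@H](CCC(=O)O)NC(=O)c1ccc(CNc2nc3cc(N)cc(N)c3nc2-c2ccccc2)cc1` likewise returns only a limit, < 100000 nM. The rest of the set is defined by the limit of < 100000 nM in this assay, at which 2 of the 3 values shown sit, so compound 1 stands as the single quantified point. Compound 4 `Nc1cc(N)c2nc(-c3ccccc3)c(NCc3ccc(F)cc3)nc2c1` remains to be measured. It differs from compound 1 by (4-fluorobenzyl)amino in place of (4-fluorophenyl)sulfanyl on an aromatic carbon. For the measured compounds named here, no measured pair spans a change of this kind, so the direction is open; a step within the scatter is expected for a 1.1-fold higher number from compound 1 to compound 4 (0.03 log units; within the scatter), with wide uncertainty. Compound 4 is accordingly estimated at 45000 nM, with a range from 12000 nM to 100000 nM.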

Compound 4, concentration for total growth inhibition: 20000 nM
Compound 4: middle estimate off by 2.3-fold (0.35 log units), on the high side; the range from low to high includes it.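

In this assay, replacing (4-fluorophenyl)sulfanyl with (4-fluorobenzyl)amino on the aromatic carbon next to the ring nitrogen gives a 2.1-fold lower number from compound 1 to compound 4 (0.32 log units; beyond the scatter). Among the compounds shown here, this is the first readable step at this position, and it runs towards stronger inhibition of growth, though only modestly. The change also brings in a hydrogen-bond donor, and this single pair cannot separate that from the added carbon.

From the compounds shown here alone, whether an unsubstituted amine or a longer chain on the nitrogen would move the number further remains open. Compound 2 and compound 3 each return only a limit, so they add no comparison: the limit of < 100000 nM in this assay, at which 2 of the 4 values shown sit.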